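Chloro in place of hydrogen: from compound 2 to compound 3

The compounds below may be only part of what the source reports. "The series", "measured", "known", "first", "only" and "open" are said of these compounds alone.

Compound 1 `O=C(COc1cccc2ccccc12)N/N=C/c1cccc(O)c1` gives 32.6 ug/mL in an ADME assay on MT4 cells (Homo sapiens) for cytotoxicity, read by MTT assay, with a stated time of 4 days; a lower number here means that less compound is tolerated, a higher number that more compound is tolerated. Compound 2 `O=C(COc1cccc2ccccc12)N/N=C/c1ccccc1` reaches only >= 96.6 ug/mL in this assay, which is a limit of the assay rather than a number. The step of an at least 2.9-fold higher number from compound 1 to compound 2 (0.47 log units; beyond the scatter) is therefore known only as a lower bound, because compound 2 sits at the limit of >= 96.6 ug/mL in this assay, at which 1 of the 2 values shown sits.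

Compound 3 `O=C(COc1cccc2ccccc12)N/N=C/c1cccc(Cl)c1` differs from compound 2 by chloro in place of hydrogen on an aromatic carbon. Going by the values given here, no measured step involves a chloro group; the single measured step, an at least 2.9-fold higher number from compound 1 to compound 2 (0.47 log units; beyond the scatter), concerns a hydroxy group on an aromatic carbon and runs upward. A modest downward step an at least 1.7-fold lower number from compound 2 to compound 3 (0.24 log units; that floor lies within the scatter) in this assay is expected. Compound 3 is estimated at 55 ug/mL, between 20 ug/mL and 100 ug/mL.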

Compound 3, half-maximal cytotoxic concentration: 89.9 ug/mL
Beside the measured number, compound 3's estimate is 1.6-fold (0.21 log units) below it; low and high end bracket the measured number.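

With chloro in place of hydroxy, a 2.8-fold higher number from compound 1 to compound 3 (0.44 log units; beyond the scatter) in this assay, so the lower number of compound 1 is not shared by every group at this place on the ring. Chloro in place of hydrogen can be read only as a floor, an at least 1.0-fold lower number from compound 2 to compound 3 (0.03 log units; that floor lies within the scatter), and that floor gives no order between the two groups. The true size of this step stays unknown, because compound 2 is a limit of the assay: the limit of >= 96.6 ug/mL in this assay, at which 1 of the 3 values shown sits.

The compounds shown leave open whether an amine or a carboxylic acid at this place would stand nearer to compound 1 or to compound 3. They also leave open whether chloro would give a similar number elsewhere on the ring.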